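The compounds below may be only part of what the source reports. "The series", "measured", "known", "first", "only" and "open" are said of these compounds alone.

Compound 1 `CC1(C)[C@H]2CC[C@]1(C)N(Cc1cn(-c3ccccc3Br)nn1)C(=O)C2`: 140 nM
Compound 2 `CC1(C)[C@H]2CC[C@]1(C)N(Cc1cn(-c3cccc(O)c3)nn1)C(=O)C2`: 370 nM

In a functional assay on OVCAR-3 cells (Homo sapiens) for inhibition, read by MTT assay, with a stated time of 24 h (on this read-out lower numbers stand for stronger inhibition and higher numbers for weaker inhibition), compound 1 gives 140 nM and stands lowest of the two numbers. Compound 2 gives 370 nM in this assay. For the measured compounds named here, the one measured step, a 2.6-fold higher number from compound 1 to compound 2 (0.42 log units; beyond the scatter), goes with 3-hydroxyphenyl in place of 2-bromophenyl on an aromatic nitrogen. Compound 3 `CC1(C)[C@H]2CC[C@]1(C)N(Cc1cn(-c3cccc(Br)c3)nn1)C(=O)C2` has not yet been measured; it differs from compound 1 by 3-bromophenyl in place of 2-bromophenyl on an aromatic nitrogen. Going by the values given here, only that single step touches the same aromatic nitrogen, and it exchanges the whole group rather than one bromophenyl for the other, so it bears on the new step only loosely. Exchanging one bromophenyl for the other is a smaller change than that, and the expected step of a 1.4-fold higher number from compound 1 to compound 3 (0.15 log units; within the scatter) in this assay is modest, close to the scatter, leaning toward a higher number. Compound 3 is therefore estimated at 200 nM, within 80 nM to 500 nM.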

Compound 3, half-maximal inhibitory concentration: 30 nM
Compound 3: the middle estimate sits 6.7-fold (0.82 log units) above what was measured; the measured number lies below the stated range.
By their numbers in this assay, from the lowest: compound 3; then compound 1; then compound 2.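

In this assay, moving the bromo alone, with the same atoms joined differently, gives a 4.7-fold lower number from compound 1 to compound 3 (0.67 log units; beyond the scatter), so on this phenyl ring the place of the bromo counts for as much as its presence. The earlier step had changed the group and its place together; the new compound separates the two, and bromo in place of hydroxy on an aromatic carbon, with the place kept, gives a 12-fold lower number from compound 2 to compound 3 (1.09 log units; beyond the scatter), which leaves 3-bromophenyl with the lowest number of the three. No measurement is at hand that speaks to what lies behind these steps.

As far as these compounds go, whether chloro, methoxy or an amine in place of the bromo on 3-bromophenyl would keep the number of compound 3 stays open. The compounds shown also leave open how 2-hydroxyphenyl would compare with 3-hydroxyphenyl, so the place of the hydroxy remains unread.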